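The source may hold more compounds than are shown below. What is called first, only, known or untested is meant among the compounds shown, and "the series" means these compounds.

Measured so far:
compound 1 `Cn1c(=O)c(=O)n(C2CCCC2)c2nc(N/N=C/c3ccc(C(F)(F)F)cc3)ncc21`, 23600 nM
compound 2 `Cn1c(=O)c(=O)n(C2CCCC2)c2nc(N/N=C/c3cccs3)ncc21`, 75600 nM
compound 3 `COc1cc(/C=N/Nc2ncc3c(n2)n(C2CCCC2)c(=O)c(=O)n3C)cc(OC)c1OC`, 17500 nM

In a functional assay on PC-3 cells (Homo sapiens) for antiproliferative activity, read by MTT assay (on this read-out lower numbers stand for stronger inhibition and higher numbers for weaker inhibition), compound 2 gives the highest of the three numbers; compound 1 gives a number a 3.2-fold higher number from compound 1 to compound 2 (0.51 log units; beyond the scatter) apart from it, and compound 3 gives the lowest number of the three. Compound 4 `CSc1ccc(/C=N/Nc2ncc3c(n2)n(C2CCCC2)c(=O)c(=O)n3C)cc1` differs from compound 2 in one place: 4-(methylsulfanyl)phenyl in place of thiophen-2-yl on a carbon with a double bond to nitrogen. Among the measured compounds shown here, the only step that bears on this change is the one from a six-membered carbon ring to thiophen-2-yl, which was a 3.2-fold higher number from compound 1 to compound 2 (0.51 log units; beyond the scatter), a modest move beyond the scatter. Going the other way, from thiophen-2-yl back to a six-membered carbon ring, compound 4 is expected to return to the region of compounds 1 and 3, a step of a 3.4-fold lower number from compound 2 to compound 4 (0.54 log units; beyond the scatter) in this assay. Compound 4 is therefore estimated at 22000 nM, with a range from 9000 nM to 55000 nM.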

Compound 4, half-maximal inhibitory concentration: 21000 nM
Estimate against measurement, compound 4: 1.0-fold (0.02 log units) above, within the range that was stated.
By their numbers in this assay, from the lowest: compounds 3, 4 and 1 (each within the scatter of the next); then compound 2.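

In this assay, 4-(methylsulfanyl)phenyl in place of thiophen-2-yl gives a 3.6-fold lower number from compound 2 to compound 4 (0.56 log units; beyond the scatter), a step beyond the scatter that involves a sulfur-bearing group on both sides. Methylsulfanyl in place of trifluoromethyl on an aromatic carbon gives a 1.1-fold lower number from compound 1 to compound 4 (0.05 log units; within the scatter), so this assay does not separate these two groups. Nothing measured here bears on the reason for either step.

Compound 2 holds the only five-membered aromatic ring shown, so it remains open whether furan-2-yl would behave like thiophen-2-yl. As far as these compounds go, how an amine or a carboxylic acid on the six-membered aromatic ring would compare also remains open.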